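The source may report more compounds than this note shows. Statements on the series, on what has been measured and on what is new or still open speak of the compounds shown alone.

Measured so far in a functional assay on NCI-H1299 cells (Homo sapiens) for inhibition, read by CCK-8 assay, with a stated time of 72 h, tested at 1 uM; a higher number here means a stronger effect of the compound at the concentration tested, a lower number a weaker effect:
compound 1, `CN(C)C(=O)c1cc2cnc(Nc3ccc(S(=O)(=O)NCCCN=C=S)cc3)nc2n1C1CCCC1`, gives 41.3%
compound 2, `CN(C)C(=O)c1cc2cnc(Nc3ccc(S(=O)(=O)NCCCCN=C=S)cc3)nc2n1C1CCCC1`, gives 29.9%
compound 3, `CN(C)C(=O)c1cc2cnc(Nc3ccc(C(=O)NCCCCCCN=C=S)cc3)nc2n1C1CCCC1`, gives 49.4%

Compound 4, `CN(C)C(=O)c1cc2cnc(Nc3ccc(C(=O)NCCCCCCCN=C=S)cc3)nc2n1C1CCCC1`, is not yet measured. It differs from compound 3 by a group of 4 heavy atoms (2 carbon, 1 nitrogen, 1 sulfur; no ring) in place of a group of 3 heavy atoms (1 carbon, 1 nitrogen, 1 sulfur; no ring), on a saturated chain carbon, six bonds along the chain from an amide-type nitrogen. The same kind of change is made between compound 1 and compound 2, where it is a group of 4 heavy atoms (2 carbon, 1 nitrogen, 1 sulfur; no ring) in place of a group of 3 heavy atoms (1 carbon, 1 nitrogen, 1 sulfur; no ring), on a saturated chain carbon, three bonds along the chain from a sulfonamide nitrogen; the place is not the same, since in that pair the group sits three bonds along the chain from a sulfonamide nitrogen, whereas in compound 4 it sits six bonds along the chain from an amide-type nitrogen. That earlier step was a number 11.4 percentage points lower from compound 1 to compound 2 (beyond the scatter). The two cores differ by a group of 12 heavy atoms (8 carbon, 2 nitrogen, 1 oxygen, 1 sulfur; no ring) in place of a group of 10 heavy atoms (4 carbon, 2 nitrogen, 2 oxygen, 2 sulfur; no ring), on an aromatic carbon; between them the step is a number 8.1 percentage points higher from compound 1 to compound 3 (within the scatter), and from the shorter chain of the other core it is a number 19.5 percentage points higher from compound 2 to compound 3 (beyond the scatter). For the measured compounds named here, for compound 4 a step of a number 10.4 percentage points lower from compound 3 to compound 4 (beyond the scatter) is expected, because the same kind of change gave a number 11.4 percentage points lower from compound 1 to compound 2 (beyond the scatter) and no second precedent exists in this set; the different place around the change widens the uncertainty. Compound 4 is thus estimated at 39%, within a range from 25% to 53%.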

Compound 4, a percentage reported as inhibition, at one concentration (the size of the read-out at that concentration, not a potency): 75.7%
Compound 4: middle estimate off by 36.7 percentage points, on the low side, and the stated range ends below it.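

Adding to the saturated chain of compound 3, at the place six bonds along from the amide-type nitrogen, gives a number 26.3 percentage points higher from compound 3 to compound 4 (beyond the scatter) in this assay. The same kind of change therefore does not carry over from the core of compound 1 to the core of compound 3 with the same direction or size: the same change on two cores in this assay, a number 11.4 percentage points lower (beyond the scatter) from compound 1 to compound 2 and a number 26.3 percentage points higher (beyond the scatter) from compound 3 to compound 4, 37.7 percentage points apart, beyond the scatter of two such steps This rests on one pair per core, and the pairs differ both in the linking group, sulfonamide or amide-type, and in the length of the chain being extended, so the data do not separate these two differences or give a general rule for chain length.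

Still open, as far as these compounds go, is whether a longer chain than that of compound 4 on the same core continues the rise or reverses it. Also open, from the compounds shown here alone, is how compound 4 would read with its chain ending in an amine or a carboxylic acid, and whether the sulfonamide series would change direction at longer chain lengths.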